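This account rests on a few compounds, and the source may have more. Where it says the series, first, only, none or still open, it means among the compounds named here.

Compound 1 (`CNc1nc(SC)nc2c1ncn2[C@@H]1C[C@@H](O)[C@H](CO)O1`): in a functional assay on U-937 cells (Homo sapiens) (on this read-out lower numbers stand for stronger inhibition and higher numbers for weaker inhibition), compound 1 reaches only the limit of the assay, > 300 uM.
Compound 2 (`CSc1nc(N(C)C)c2ncn([C@@H]3C[C@@H](O)[C@H](CO)O3)c2n1`): in this assay compound 2 gives 126 uM.

Compound 2 holds the only numerical result in this assay; the other value is a limit, and for compound 1 that result is the limit of > 300 uM in this assay, at which 1 of the 2 values shown sits. Among the measured compounds shown here, the one measured step is an at least 2.3-fold lower number from compound 1 to compound 2 (0.37 log units; beyond the scatter), so adding a methyl on that nitrogen made the inhibition stronger.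

Compound 3 (`CSc1nc(N)c2ncn([C@@H]3C[C@@H](O)[C@H](CO)O3)c2n1`) differs from compound 2 by amino in place of dimethylamino on an aromatic carbon. This removes both methyl groups from the nitrogen that carried two methyls in compound 2 and one in compound 1. For the measured compounds named here, the only measured step runs the other way: taking a methyl away brought compound 1 to the limit, so taking two away from compound 2 is expected to raise the number, most likely back toward or beyond the limit. The expected step of a 2.4-fold higher number from compound 2 to compound 3 (0.38 log units; beyond the scatter) therefore points toward weaker inhibition. Compound 3 is expected to give 300 uM, within a range from 100 uM to 1000 uM.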

Compound 3, concentration for 50% inhibition: > 300 uM
Compound 3: a limit, no number; the forecaster's own chance of this, stated with the estimate: 50%; the middle value sits exactly at the limit.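

Replacing dimethylamino with amino on this aromatic carbon gives an at least 2.3-fold higher number from compound 2 to compound 3 (0.37 log units; beyond the scatter), which means weaker inhibition in this assay and shows that removing both methyl groups costs activity. Compound 3 gives > 300 uM, which is a limit of the assay and not a number. Of the three compounds, only the one with two methyl groups on this nitrogen gives a number, while the step between the methylamino and amino compounds cannot be read because both rest on the same limit: the limit of > 300 uM in this assay, at which 2 of the 3 values shown sit.

As far as these compounds go, it remains open whether a larger group at this position, such as diethylamino or a nitrogen carrying a longer chain, would lower the number further or lose the gain seen with dimethylamino. From the compounds shown here alone, the methylsulfanyl group is the same in all three compounds, so the effect of an ethylsulfanyl group or a plain hydrogen in its place on the dimethylamino compound also remains unknown.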